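This account rests on a few compounds, and the source may have more. Where it says the series, first, only, none or still open, it means among the compounds named here.

Of the compounds shown here, three sharing one core have been measured in a functional assay on CAKI-1 cells (Homo sapiens) for inhibition, read by sulforhodamine B assay, with a stated time of 48 h, tested at 10 uM; on this read-out higher numbers stand for more inhibition of growth at the one concentration tested and lower numbers for less inhibition of growth. Compound 1 `O=C(O)c1ccc(Nc2ccnc(SCC(=O)c3ccc(C(F)(F)F)cc3)n2)cc1` gives 19%. Compound 2 `CC(=O)c1cccc(Nc2ccnc(SCC(=O)c3ccc(-c4ccccc4)cc3)n2)c1` gives 23%. Compound 3 `CC(=O)c1ccc(Nc2ccnc(SCC(=O)c3ccc(Cl)cc3)n2)cc1` gives 21%. Among these three numbers compound 2 stands highest, yet the nearest number, that of compound 3, lies within the scatter, and so does the furthest, that of compound 1; the three values therefore cannot be told apart, and none of them can be called the most active.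

The next compound, compound 4 `COc1ccc(C(=O)CSc2nccc(Nc3cccc(C(C)=O)c3)n2)cc1`, differs from compound 2 in one place: methoxy in place of phenyl on an aromatic carbon. Everything else in the molecule is kept.

Among the compounds with values here, no pair of measured compounds differs in only one place, so there is no measured step to lean on. What the numbers do show is that three quite different groups on that aryl ring all sit within the scatter of one another in this assay. On that basis the step from compound 2 to compound 4 is expected to be a number 3 percentage points lower from compound 2 to compound 4 (within the scatter), that is, no change beyond the scatter in either direction. Compound 4 is accordingly estimated at 20%, with a range from 8% to 32%.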

Compound 4, percent growth inhibition at one concentration: 35%
Estimate against measurement, compound 4: 15 percentage points below, and the stated range ends below it.
By their numbers in this assay, from the lowest: compounds 1, 3 and 2 (each within the scatter of the next); then compound 4.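

In this assay, within the data shown here, the swap of phenyl for methoxy, on an aromatic carbon para to a large group, amounts to a number 12 percentage points higher from compound 2 to compound 4 (beyond the scatter) and is the one step in this set that can be read as a real change, so what sits at this position does matter for this read-out. The swap removes a six-membered aromatic ring of six carbon atoms and puts in a group of only two heavy atoms that carries one hydrogen-bond acceptor, which shows that the outer phenyl ring is not needed to reach the higher number of compound 4. Nothing available here explains why the number rises.

A single step cannot separate the loss of the ring from the arrival of the oxygen, and a hydroxy group, an ethoxy group or a longer alkoxy chain at this position would help to tell those two apart. Going by these compounds, it also remains open whether methoxy gives a similar step when the acetyl group on the other aromatic ring is replaced, for example by a carboxylic acid.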